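Amide replacement on the shared core: compound 3 to compound 4

This account rests on a few compounds, and the source may have more. Where it says the series, first, only, none or still open, it means among the compounds named here.

Of the compounds shown here, three on a shared core have been measured in an assay on CHO cells for displacement of a labelled ligand from histamine receptor H3 (Macaca mulatta); on this read-out lower numbers stand for stronger inhibition and higher numbers for weaker inhibition. Compound 1 `Cc1cc(N2CC[C@H](N3CCC[C@@H]3C)C2)ccc1NC(=O)C1C(C)(C)C1(C)C` gives 0.55 nM. Compound 2 `Cc1cc(NC(=O)C2CC2)ccc1N1CCC(N2CCCC2C)C1` gives 17.7 nM. Compound 3 `Cc1cc(N2CCC(N3CCCC3C)C2)ccc1NC(=O)C1CC2CCC1C2` gives 19.9 nM, the highest of the three numbers; its gap to compound 2 lies within the scatter, so no order between these two can be read, while its gap to compound 1 lies beyond the scatter, with compound 1 at the lower number.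

Compound 4 `Cc1cc(N2CCC(N3CCCC3C)C2)ccc1NC(=O)C1CCOCC1` is not yet measured. It differs from compound 3 in one place: a group of 6 heavy atoms (5 carbon, 1 oxygen; one six-membered non-aromatic ring with 1 hetero atom) in place of a group of 7 heavy atoms (7 carbon; 2 five-membered non-aromatic rings of carbon only), on a carbonyl carbon. Going by the values given here, no step between two measured compounds isolates this kind of change. What the measured numbers show is that compound 2 and compound 3 carry different amide groups yet give values within the scatter of each other.

For compound 4 in this assay no step beyond the scatter is expected: a 1.0-fold higher number from compound 3 to compound 4 (0.00 log units; within the scatter). The estimate for compound 4 is 20 nM, with a range from 6 nM to 65 nM.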

Compound 4, inhibition constant: 6.8 nM
Beside the measured number, compound 4's estimate is 2.9-fold (0.47 log units) above it, within the range that was stated.
By their numbers in this assay, from the lowest: compound 1; then compound 4; then compounds 2 and 3 (each within the scatter of the next).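

In this assay the amide position now shows that it can tell two groups apart: with oxan-4-yl in place of the carbon-only group of 7 heavy atoms on the carbonyl carbon, the result is a 2.9-fold lower number from compound 3 to compound 4 (0.47 log units; beyond the scatter). Going by these compounds alone, compound 2 and compound 3 carry different amide groups and had given values within the scatter of each other, so the earlier compounds showed no such separation between a pair differing only at this place. No measurement at hand says what lies behind this step.

Still open, from the compounds shown here alone, is whether the step goes with the ring oxygen or with the change of ring as a whole, a question that a cyclohexyl group on this carbonyl carbon would address. How an amine in the same ring, as in piperidin-4-yl, would read in this assay is open as well.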